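A few compounds are considered here, and "the series" means these few. Any claim that something is new, unique, unknown or untested is made for them only; others in the source may bear on it.

Of the compounds shown here, three built on one shared core have been measured in an in vitro functional assay on HEK293 cells for antagonist activity at melanin-concentrating hormone receptor 1 (Homo sapiens), read by GTPgammaS binding, with a stated time of 45 min; on this read-out lower numbers stand for lower potency and higher numbers for higher potency (the scale is a negative logarithm). Compound 1 `Cc1ccc(CN2CCC(NC(=O)NCc3ccc(-c4ccc(F)cc4)cc3)CC2)cc1` gives 6.71. Compound 2 `Cc1ccc(CN2CCC(NC(=O)NCc3ccc(-c4cccc(C#N)c4)cc3)CC2)cc1` gives 6.39. Compound 3 `Cc1ccc(CN2CCC(NC(=O)N(CC(=O)C(C)(C)O)Cc3ccc(-c4ccc(F)cc4)cc3)CC2)cc1` gives 5.34. Compound 3 stands lowest of the three: compound 2 is its nearest neighbour above it, and compound 1 lies furthest above it. Two single-point steps link the measured compounds. Exchanging the 4-fluorophenyl group for 3-cyanophenyl, a number 0.32 log units lower from compound 1 to compound 2 (beyond the scatter), was a modest loss. Placing the ((1-hydroxy-1-methylethyl)carbonyl)methyl group on the amide-type nitrogen, a number 1.37 log units lower from compound 1 to compound 3 (beyond the scatter), was a large loss.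

Compound 4 `COc1ccccc1-c1ccc(CN(CC(=O)C(C)(C)O)C(=O)NC2CCN(Cc3ccc(C)cc3)CC2)cc1` has not yet been measured. It differs from compound 3 in one place: 2-methoxyphenyl in place of 4-fluorophenyl on an aromatic carbon. For the measured compounds named here, of the measured steps, only the one from compound 1 to compound 2 bears on this change, as it too replaces the 4-fluorophenyl group on that aromatic carbon; the step from compound 1 to compound 3 concerns a different site. Since that comparable step was modest, a small downward step, or none beyond the scatter, is expected in this assay. The expected step is a number 0.14 log units lower from compound 3 to compound 4 (within the scatter). Compound 4 is estimated at 5.2, with a range from 4.6 to 5.8.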

Compound 4, negative logarithm of the antagonist equilibrium constant: 5.43
The estimate for compound 4 lay 0.23 log units below the measured number; the measured number falls inside the stated range.
By their numbers in this assay, from the lowest: compounds 3 and 4 (each within the scatter of the next); then compound 2; then compound 1.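

In this assay, the exchange of 4-fluorophenyl for 2-methoxyphenyl, a number 0.09 log units higher from compound 3 to compound 4 (within the scatter), stays within the scatter, so this aromatic carbon accepts a second aryl group without a measurable change when the ((1-hydroxy-1-methylethyl)carbonyl)methyl group sits on the amide-type nitrogen. For the compounds shown here, the earlier step at this place, a number 0.32 log units lower from compound 1 to compound 2 (beyond the scatter), was a different exchange, made with the amide hydrogen in place, and lay beyond the scatter; the new pair is the first reading at this position on the substituted nitrogen, and it shows that a group with one hydrogen-bond acceptor can replace one with none here without a change beyond the scatter. Nothing available explains why the number holds across this exchange.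

The compounds shown leave open whether 2-methoxyphenyl would also leave the number unchanged with the amide hydrogen in place, and whether 3-cyanophenyl would carry its step over to the substituted nitrogen. They also leave open how an aryl group bearing an amine or a carboxylic acid would read at this aromatic carbon on either background.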